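This account rests on a few compounds, and the source may have more. Where it says the series, first, only, none or still open, it means among the compounds named here.

Measured so far in a functional assay on MCF7 cells (Homo sapiens) for inhibition, with a stated time of 48 h; a lower number here means a stronger inhibitor of growth, a higher number a weaker inhibitor of growth:
compound 1 `Nc1ncnc2c1cnn2-c1ccc(C(=O)O)cc1`: "not determined" (no result reported)
compound 2 `N#Cc1cnn(-c2ccc(C(F)(F)F)cc2)c1N`: a limit only, > 150000 nM
compound 3 `CC(=O)OC[C@H]1O[C@@H](Nc2ncnc3c2cnn3-c2ccc(C(=O)O)cc2)[C@H](OC(C)=O)[C@@H](OC(C)=O)[C@@H]1OC(C)=O`: a limit only, > 150000 nM

For the measured compounds named here, compound 2 therefore stands at the limit of > 150000 nM in this assay, at which 2 of the 3 values shown sit; no number for it is known, and no pair of measured compounds differs in a single place, so no measured step exists.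

Compound 4 `N#Cc1cnn(-c2ccc([N+](=O)[O-])cc2)c1N` is next, differing from compound 2 by nitro in place of trifluoromethyl on an aromatic carbon. With the series giving nothing but limits and one missing entry, no step beyond the scatter is expected in this assay in either direction. Compound 4 is estimated at 150000 nM (range 40000 nM to 600000 nM), most likely reported as a limit again, which is a step of a number no higher from compound 2 to compound 4 (the limit leaves the size open).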

Compound 4, concentration for 50% growth inhibition: 64000 nM
Compound 4: middle estimate off by 2.3-fold (0.37 log units), on the high side; the measured number falls inside the stated range.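

At this aromatic carbon, para to a group of 8 heavy atoms, the substituent registers in this assay: nitro in place of trifluoromethyl gives an at least 2.3-fold lower number from compound 2 to compound 4 (0.36 log units; beyond the scatter). This is the only step in the series, and compound 4 is the only compound shown with a number rather than a limit. The true size of the step stays open because its starting point is only a limit: the limit of > 150000 nM in this assay, at which 2 of the 4 values shown sit.

As far as these compounds go, whether this response is particular to nitro remains open, as an amine, a chlorine atom or a methoxy group at this carbon would show.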